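Chloro-to-nitro swap on the benzoxazolone core, furfuryl amide series

The compounds below may be only part of what the source reports. "The series", "measured", "known", "first", "only" and "open" are said of these compounds alone.

Compound 1 `O=C(Cn1c(=O)oc2cc(Cl)ccc21)NCc1ccco1` is measured in an ADME assay on RAW264.7 cells (Mus musculus) for cytotoxicity, read by MTT assay, with a stated time of 72 h, tested at 50 uM (on this read-out higher numbers stand for a stronger effect at the one concentration tested and lower numbers for a weaker effect), at 27.8% and stands highest of the three values known. Compound 2 `O=C(Cn1c(=O)oc2cc(Cl)ccc21)Nc1nc2ccc([N+](=O)[O-])cc2s1` gives 12.5% in this assay, and compound 3 `O=C(Cn1c(=O)oc2cc([N+](=O)[O-])ccc21)Nc1nc2ccc([N+](=O)[O-])cc2s1` gives 14.8%. The difference between the core of compound 1 and that of compound 2 is not broken down here. Compound 2 and compound 3 differ by nitro in place of chloro on an aromatic carbon and this change moves the read-out by a number 2.3 percentage points higher from compound 2 to compound 3 (within the scatter). Compound 4 `O=C(Cn1c(=O)oc2cc([N+](=O)[O-])ccc21)NCc1ccco1` is not yet measured; it differs from compound 1 by the same change, (nitro in place of chloro on an aromatic carbon). Because the step of a number 2.3 percentage points higher from compound 2 to compound 3 (within the scatter) lies within the scatter, compound 4 is expected to stay close to compound 1, with an estimated step of a number 2.2 percentage points higher from compound 1 to compound 4 (within the scatter). For compound 4 the estimate in this assay is 30%, between 16% and 44%.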

Compound 4, a percentage reported as inhibition, at one concentration (the size of the read-out at that concentration, not a potency): 26.8%
Compound 4: the middle estimate sits 3.2 percentage points above what was measured; low and high end bracket the measured number.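

In this assay, nitro in place of chloro on an aromatic carbon gives a small step on the second core, a number 1 percentage points lower from compound 1 to compound 4 (within the scatter). Set beside the earlier step, the change carries over with no difference that can be read: the same change on two cores in this assay, a number 2.3 percentage points higher (within the scatter) from compound 2 to compound 3 and a number 1 percentage points lower (within the scatter) from compound 1 to compound 4, 3.3 percentage points apart, within the scatter of two such steps This holds only for the two pairs shown, where neither step stands out from the scatter, and it does not show how the change would behave on another core or at another concentration.

The compounds shown leave open whether a different group on that aromatic carbon, such as an amine or a carboxylic acid, would move the read-out beyond the scatter. As far as these compounds go, whether any such replacement behaves alike on both cores also stays open.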